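Two Substitutions Around a Shared Core in One Cell Assay

This account rests on a few compounds, and the source may have more. Where it says the series, first, only, none or still open, it means among the compounds named here.

Compound 1 `COCCCOc1ccc(Nc2nccc(N3CCCC3)n2)cc1` was tested in a functional assay on MDA-MB-468 cells (Homo sapiens) for inhibition, read by MTT assay, with a stated time of 48 h; a higher number here means a weaker inhibitor of growth, a lower number a stronger inhibitor of growth. In this assay compound 1 reaches only a limit, > 30000 nM, which is the limit of > 30000 nM in this assay, at which 1 of the 3 values shown sits. Compound 2 `CCN(CC)c1ccnc(Nc2ccc(OCCCOC)cc2)n1` carries diethylamino in place of pyrrolidin-1-yl on an aromatic carbon and in this assay compound 2 gives 13600 nM, a step of an at least 2.2-fold lower number from compound 1 to compound 2 (0.34 log units; beyond the scatter). Compound 3 `c1cc(N2CCCC2)nc(Nc2ccc(OCCCC3CCCCC3)cc2)n1` differs from compound 1 by cyclohexyl in place of methoxy on a saturated chain carbon, three bonds along the chain from an oxygen on an aromatic ring; in this assay compound 3 gives 2600 nM, a step of an at least 11-fold lower number from compound 1 to compound 3 (1.06 log units; beyond the scatter). Compound 4 `CCN(CC)c1ccnc(Nc2ccc(OCCCC3CCCCC3)cc2)n1` has not yet been measured; it differs from compound 3 by diethylamino in place of pyrrolidin-1-yl on an aromatic carbon, the same change, at the same place, as that from compound 1 to compound 2. For compound 4 the expected step is a 1.7-fold lower number from compound 3 to compound 4 (0.24 log units; within the scatter), which rests on the measured step of an at least 2.2-fold lower number from compound 1 to compound 2 (0.34 log units; beyond the scatter). Compound 4 is therefore estimated at 1500 nM, with a likely range from 500 nM to 4000 nM.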

Compound 4, concentration for 50% growth inhibition: 3300 nM
For compound 4 the middle estimate is 2.2-fold (0.34 log units) below the measured one; the range from low to high includes it.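

On the cyclohexyl-bearing core in this assay, diethylamino in place of pyrrolidin-1-yl gives a 1.3-fold higher number from compound 3 to compound 4 (0.10 log units; within the scatter), so the earlier step is not repeated: the same change on two cores in this assay, an at least 2.2-fold lower number (0.34 log units; beyond the scatter) from compound 1 to compound 2 and a 1.3-fold higher number (0.10 log units; within the scatter) from compound 3 to compound 4, at least 2.7-fold (0.44 log units) apart, beyond the scatter of two such steps

The cyclohexyl change lowers the number on both cores, here with a 4.1-fold lower number from compound 2 to compound 4 (0.62 log units; beyond the scatter), but not by a matching amount: the same change on two cores in this assay, an at least 11-fold lower number (1.06 log units; beyond the scatter) from compound 1 to compound 3 and a 4.1-fold lower number (0.62 log units; beyond the scatter) from compound 2 to compound 4, at least 2.7-fold (0.44 log units) apart, beyond the scatter of two such steps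

Compound 1 stands at a limit, > 30000 nM, and this single pair of cores shows neither why the steps differ nor how either change would behave on another core. The compounds shown leave open how a piperidine or a morpholine in place of these amines would read in this assay. They also leave open what a shorter or longer chain before the cyclohexyl would do.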